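Expected Vero cell cytotoxicity after a nitro-to-phenoxy exchange

This account rests on a few compounds, and the source may have more. Where it says the series, first, only, none or still open, it means among the compounds named here.

Measured compounds and their values:
compound 1, `COc1ccc2c(c1)[C@@H](O)CN(C)C2`: > 100000 nM
compound 2, `CN1Cc2ccc(OCc3ccc(-c4ccccc4)cc3)cc2[C@@H](O)C1`: 23000 nM
compound 3, `CN1Cc2ccc(OCc3ccc([N+](=O)[O-])cc3)cc2[C@@H](O)C1`: > 50000 nM

All three compounds share one core and were tested in an ADME assay on Vero cells (Chlorocebus sabaeus) for cytotoxicity, read by sulforhodamine B assay, with a stated time of 72 h; a higher number here means a weaker inhibitor, a lower number a stronger inhibitor. Compound 1 reaches only a limit there, namely (the limit of > 100000 nM in this assay, at which 1 of the 3 values shown sits). Compound 3 likewise reaches only a limit, (the limit of > 50000 nM in this assay, at which 1 of the 3 values shown sits). Compound 2 alone gives a number.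

Within the data shown here, the single measured step is an at least 2.1-fold higher number from compound 2 to compound 3 (0.33 log units; beyond the scatter), in which nitro replaces phenyl on an aromatic carbon; since compound 3 is at a limit, only a least size of that step is known.

Compound 4, `CN1Cc2ccc(OCc3ccc(Oc4ccccc4)cc3)cc2[C@@H](O)C1`, has not yet been measured. It differs from compound 3 by phenoxy in place of nitro on an aromatic carbon.

The measured step bears on it directly, since it runs in the reverse sense: where a ring gave way to nitro, here nitro gives way to a group that brings in a ring again, as in compound 2, which gave 23000 nM. Compound 4 is therefore expected to show a step of an at least 1.6-fold lower number from compound 3 to compound 4 (0.22 log units; that floor lies within the scatter), a downward move out of the limit region. Compound 4 is estimated at 30000 nM, with a range from 10000 nM to 100000 nM.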

Compound 4, half-maximal inhibitory concentration: 3400 nM
Compound 4: middle estimate off by 8.8-fold (0.95 log units), on the high side; the whole stated range lies above it.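

In this assay, among these compounds, this aromatic carbon, para to a large group, proves far more sensitive to its substituent than the earlier compounds could show: phenoxy in place of nitro gives an at least 14-fold lower number from compound 3 to compound 4 (1.16 log units; beyond the scatter) and phenoxy in place of phenyl gives a 6.8-fold lower number from compound 2 to compound 4 (0.83 log units; beyond the scatter) at the same place. The second step shows that bringing back a six-membered aromatic ring is not the whole story, since two substituents that both carry such a ring still differ beyond the scatter, and the one joined through oxygen gives the lower number. The first step has only a least size, and its true size stays unknown, because compound 3 stands at a limit of the assay: the limit of > 50000 nM in this assay, at which 1 of the 4 values shown sits.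

The compounds shown leave open whether the ring in phenoxy matters as an aromatic ring at all, as a cyclohexyloxy group, a benzyloxy group or a plain butoxy chain at this place would test. They also leave open how far the number would move with a chlorine or a carboxylic acid on the phenoxy ring.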